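Swapping the aryl group on a piperazine sulfonyl

The source may hold more compounds than are shown below. What is called first, only, known or untested is meant among the compounds shown, and "the series" means these compounds.

Measured so far in a functional assay on MCF7 cells (Homo sapiens) for cytotoxicity, read by MTT assay, with a stated time of 48 h; a lower number here means a stronger inhibitor, a higher number a weaker inhibitor: compound 2 `CCN(CC)c1ccc2cc(C(=O)c3ccc(N4CCN(S(=O)(=O)c5ccc(Br)c(F)c5)CC4)cc3)oc2c1` gives 2270 nM, and compound 1 `CCN(CC)c1ccc2cc(C(=O)c3ccc(N4CCN(C(=O)COc5ccc(Cl)cc5Cl)CC4)cc3)oc2c1` gives 12400 nM.

Compound 2 holds the lowest of the two numbers; the step of a 5.5-fold lower number from compound 1 to compound 2 (0.74 log units; beyond the scatter) lies beyond the scatter. Compound 3 `CCN(CC)c1ccc2cc(C(=O)c3ccc(N4CCN(S(=O)(=O)c5ccc(C)cc5)CC4)cc3)oc2c1` keeps the shared core and the sulfonyl link and differs only here: 4-methylphenyl in place of 4-bromo-3-fluorophenyl on a sulfonyl sulfur. Going by the values given here, no measured step changes the aryl group on this sulfonyl sulfur, so the step from compound 2 to compound 3 is judged without a direct precedent, and no shift beyond the scatter is expected, a 1.5-fold higher number from compound 2 to compound 3 (0.19 log units; within the scatter). Compound 3 is therefore estimated at 3500 nM in this assay, within 1200 nM to 10000 nM.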

Compound 3, half-maximal inhibitory concentration: > 40000 nM
Compound 3 gave a limit, no number; the forecaster's own chance of this, stated with the estimate: 5%; middle value at least 11-fold (1.05 log units) away from the limit.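

On this sulfonyl sulfur the aryl group matters in this assay: 4-methylphenyl in place of 4-bromo-3-fluorophenyl gives an at least 17-fold higher number from compound 2 to compound 3 (1.24 log units; beyond the scatter) and so decides the result. The sulfonyl link does not help by itself, since a 5.5-fold lower number from compound 1 to compound 2 (0.74 log units; beyond the scatter) runs one way while an at least 3.2-fold higher number from compound 1 to compound 3 (0.50 log units; beyond the scatter) runs the other. The value of compound 3 is a limit and not a number: the limit of > 40000 nM in this assay, at which 1 of the 3 values shown sits.

The compounds shown leave open whether the bromine, the fluorine or both account for the lower number of compound 2. They also leave open how a phenyl carrying an amine would read on this sulfur.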